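This account rests on a few compounds, and the source may have more. Where it says the series, first, only, none or still open, it means among the compounds named here.

Measured compounds:
- compound 1 `CCNC(=O)c1cc(Oc2ccc(NC(=O)c3cc4cccnc4n(-c4ccc(Br)cc4F)c3=O)cc2)ccn1`: 10300 nM
- compound 2 `CCNC(=O)c1cc(Oc2ccc(NC(=O)c3cc4cccnc4n(-c4ccc(F)c(Cl)c4)c3=O)cc2)ccn1`: "not determined" (no result reported)

For the measured compounds named here, only one of the two compounds carries a number. In a functional assay on U-87MG ATCC cells for antiproliferative activity against U-87 MG (Homo sapiens), read by MTT assay, with a stated time of 72 h (a lower number here means a stronger inhibitor, a higher number a weaker inhibitor), compound 1 gives 10300 nM, which on the scale of this read-out is a weak result. In this assay, going by the values given here, compound 2 is recorded as "not determined" (no result reported), so it stands without a measured value, and no step between compound 1 and compound 2 can be drawn from the data.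

Compound 3 `CCCNC(=O)c1cc(Oc2ccc(NC(=O)c3cc4cccnc4n(-c4ccc(F)c(Cl)c4)c3=O)cc2)ccn1` is the compound still to be measured. It differs from compound 2 by methyl in place of hydrogen on a saturated chain carbon, two bonds along the chain from an amide-type nitrogen. Since no measured step of this kind exists among these compounds, there is nothing to point to a direction; a change as small as this one, adding a single carbon to the chain on the amide-type nitrogen, is expected to move the number in this assay by no more than the usual scatter, if at all.

Compound 3 is therefore expected to come in at about 10000 nM, with a likely range from 3000 nM to 30000 nM.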

Compound 3, half-maximal inhibitory concentration: 3590 nM
Beside the measured number, compound 3's estimate is 2.8-fold (0.44 log units) above it; low and high end bracket the measured number.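

In this assay, for the compounds shown here, compound 3 gives 3590 nM but compound 2 carries no number, so no step between compound 2 and compound 3 can be read. No measurement shown here offers an explanation for this value. The compounds shown leave open how the change from ethylamino to propylamino alone moves the antiproliferative activity.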